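This account rests on a few compounds, and the source may have more. Where it says the series, first, only, none or still open, it means among the compounds named here.

Compound 2 `C/C(=C\c1cc(-c2ccc([N+](=O)[O-])cc2)cs1)C(N)=O` and compound 1 `C/C(=C\c1cc(-c2ccc(F)cc2)cs1)C(N)=O` share the same core and differ only in one group on the six-membered ring. In an ADME assay on NIH3T3 cells (Mus musculus) for cytotoxicity, read by CCK-8 assay, with a stated time of 24 h (on this read-out lower numbers stand for stronger inhibition and higher numbers for weaker inhibition), compound 1 gives > 50000 nM, which is a limit of the assay rather than a number. In this assay compound 2 gives > 50000 nM, again only a limit. Both values sit at the limit of > 50000 nM in this assay, at which 2 of the 2 values shown sit, so the step that the two limits leave unreadable from compound 1 to compound 2 has no readable size. Compound 3 `C/C(=C\c1cc(-c2ccc(Cl)cc2)cs1)C(N)=O` is the next member of the series: chloro in place of nitro on an aromatic carbon. Among the measured compounds shown here, the single measured step is the only one that bears on this change, and since both of its ends are limits, it gives no size in this assay and no direction. Compound 3 is therefore expected to stay weak as well, and the expected step that the limit leaves unreadable from compound 2 to compound 3 is none that can be stated beyond the scatter. Compound 3 is estimated at 80000 nM, with a range from 30000 nM to 300000 nM.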

Compound 3, half-maximal inhibitory concentration: > 50000 nM
Compound 3 gave a limit, no number; the forecaster's own chance of this, stated with the estimate: 85%; the middle value lies beyond the limit too.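

The steps among compound 1, compound 2 and compound 3 cannot be read, in size or in direction, because each compound gives only a limit and no number: the limit of > 50000 nM in this assay, at which 3 of the 3 values shown sit.

The compounds shown leave open whether fluoro, nitro and chloro differ at all in this assay.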